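Chloro on the carboxyphenyl ring: compound 2 to compound 4

This account rests on a few compounds, and the source may have more. Where it says the series, first, only, none or still open, it means among the compounds named here.

Measured compounds, all in an assay on HEK293 cells for positive allosteric modulation of metabotropic glutamate receptor 2 (Rattus norvegicus), read by thallium flux, with a stated time of 2.5 min; on this read-out lower numbers stand for smaller maximal responses and higher numbers for larger maximal responses:
compound 1 `Cc1c(OCCCCOc2ccc(C(=O)O)cc2)ccc(C(=O)CC(C)C)c1O` gives 88%
compound 2 `Cc1c(OCCCCOc2ccc(C(=O)O)cc2)ccc(C(=O)CC(C)C)c1C` gives 19%
compound 3 `COc1cc(C(=O)O)ccc1OCCCCOc1ccc(C(C)=O)c(O)c1C` gives 86.3%

Compound 2 stands lowest of the three numbers. Compound 3, its nearest neighbour, sits far above it, and compound 1 sits furthest above it; both gaps are well beyond the scatter. Among the measured compounds shown here, the one step measured within the set, a number 69 percentage points lower from compound 1 to compound 2 (beyond the scatter), is a change on the shared core and is large. For the measured compounds named here, compound 3 shares the hydroxy core feature of compound 1 and its value lies close to that of compound 1, though no single-change step links compound 3 to either.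

Compound 4 `Cc1c(OCCCCOc2ccc(C(=O)O)c(Cl)c2)ccc(C(=O)CC(C)C)c1C` differs from compound 2 by chloro in place of hydrogen on an aromatic carbon. Going by the values given here, this change sits on the carboxyphenyl end of the molecule, which none of the measured steps touches; the only measured step concerns the core. Nothing in the set therefore speaks for a change in this assay from such a substitution, and the working expectation is a step of a number 3 percentage points higher from compound 2 to compound 4 (within the scatter), that is none beyond the scatter. Among the compounds with values here, compound 4 is accordingly estimated at 22% in this assay, with a range from 8% to 45%, the width reflecting that no measured step bears directly on the change.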

Compound 4, largest response reached (reported as percent of maximum), in percent of the reference or control that the assay uses: 33.1%
The estimate for compound 4 lay 11.1 percentage points below the measured number, and the stated range covers the measured number.
By their numbers in this assay, from the lowest: compound 2; then compound 4; then compounds 3 and 1 (each within the scatter of the next).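

Working notes on the carboxyphenyl end: in this assay, the change from 4-carboxyphenyl to 4-carboxy-3-chlorophenyl gives a number 14.1 percentage points higher from compound 2 to compound 4 (beyond the scatter) and is the first measured step at this end of the molecule. The response therefore moves with a single chloro placed ortho to the carboxy group and meta to the large group, so this position cannot be treated as silent in compounds that carry methyl in place of hydroxy on the shared core. Nothing available explains the step or ties it to any property of chloro.

As far as these compounds go, whether chloro gives a similar step on the core of compound 1, where the hydroxy group is present and the response is already high, remains open. Also open, from the compounds shown here alone, is how other groups at this same place, such as fluoro, bromo, methyl or trifluoromethyl, would compare with chloro, and whether the step depends on chloro itself or would follow from any group replacing hydrogen here.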